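This account rests on a few compounds, and the source may have more. Where it says the series, first, only, none or still open, it means among the compounds named here.

Three measured compounds share one core and differ only in the group on an oxygen on an aromatic ring. In an assay on cells for binding affinity to Neuropeptide Y receptor type 1 (Homo sapiens) (a lower number here means a stronger inhibitor, a higher number a weaker inhibitor), compound 1 `CCOc1cc(CCc2nc(C)c(CC)s2)nc(NCc2cc(Cl)cc(NC(=O)OC(C)C)c2)c1` gives 33 nM, compound 2 `CCCCOc1cc(CCc2nc(C)c(CC)s2)nc(NCc2cc(Cl)cc(NC(=O)OC(C)C)c2)c1` gives 16 nM, and compound 3 `CCCCCOc1cc(CCc2nc(C)c(CC)s2)nc(NCc2cc(Cl)cc(NC(=O)OC(C)C)c2)c1` gives 35 nM. Compound 3 has the highest number of the three: its gap to compound 1 lies within the scatter, while the step of a 2.2-fold higher number from compound 2 to compound 3 (0.34 log units; beyond the scatter) lies beyond it. Compound 4 `CCc1sc(CCc2cc(OC3CCC3)cc(NCc3cc(Cl)cc(NC(=O)OC(C)C)c3)n2)nc1C` alters this group once more: cyclobutyl in place of pentyl on an oxygen on an aromatic ring. The step of a 1.1-fold higher number from compound 1 to compound 3 (0.03 log units; within the scatter) and the step from compound 2 show that changing the length of this chain moves this assay at most modestly, so a modest downward step or none beyond the scatter is expected. Compound 4 is therefore estimated at 20 nM, within a range from 8 nM to 50 nM, an expected step of a 1.8-fold lower number from compound 3 to compound 4 (0.24 log units; within the scatter).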

Compound 4, half-maximal inhibitory concentration: 11 nM
Beside the measured number, compound 4's estimate is 1.8-fold (0.26 log units) above it; the measured number falls inside the stated range.
By their numbers in this assay, from the lowest: compounds 4 and 2 (each within the scatter of the next); then compounds 1 and 3 (each within the scatter of the next).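

With a 3.2-fold lower number from compound 3 to compound 4 (0.50 log units; beyond the scatter) on replacing pentyl and a 3.0-fold lower number from compound 1 to compound 4 (0.48 log units; beyond the scatter) on replacing ethyl, cyclobutyl on this oxygen does better than those two chains, so a ring is accepted at this place, something the straight chains alone could not show. Against butyl, a 1.5-fold lower number from compound 2 to compound 4 (0.16 log units; within the scatter) leaves the two level, so the ring does not go past the butyl chain.

Nothing available gives a reason for these steps. From the compounds shown here alone, whether cyclopropyl, cyclopentyl or a branched chain such as isopropyl would keep this level stays open.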